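Ketone chain trimming in a metabotropic glutamate receptor 3 series

The compounds below may be only part of what the source reports. "The series", "measured", "known", "first", "only" and "open" are said of these compounds alone.

Measured compounds
- compound 1, `CCCC(=O)c1ccc(OCCCCOc2cccc(C(=O)O)c2C)c(C)c1O`: 53%
- compound 2, `Cc1c(OCCCCOc2ccc(C(=O)C(C)C)c(O)c2C)cccc1C(=O)O`: 27.1%
- compound 3, `COC(=O)c1ccc(OCCCCOc2ccc(C(=O)CC3CCCC3)c(C)c2C)cc1`: 24.2%

In an assay on HEK293 cells for positive allosteric modulation of metabotropic glutamate receptor 3 (Rattus norvegicus), read by thallium flux, with a stated time of 2.5 min (on this read-out higher numbers stand for larger maximal responses and lower numbers for smaller maximal responses), compound 2 gives 27.1%, the second highest of the three numbers. Compound 3 sits nearest to it, within the usual scatter, so the two cannot be ordered; compound 1 lies furthest away and beyond the scatter, as a number 25.9 percentage points lower from compound 1 to compound 2 (beyond the scatter) shows.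

Compound 4, `CCC(=O)c1ccc(OCCCCOc2cccc(C(=O)O)c2C)c(C)c1O`, has not been measured in this assay. It differs from compound 2 in one place: hydrogen in place of methyl on a saturated chain carbon bound to a carbonyl carbon and a saturated chain carbon. Cut one bond further out, this reads isopropyl to ethyl, or isopropylcarbonyl to propanoyl.

Among the measured compounds shown here, the only measured step that bears on this change is the one on the same carbonyl carbon, a number 25.9 percentage points lower from compound 1 to compound 2 (beyond the scatter), a modest loss when branching was introduced at this carbon. Compound 4 removes that branching again while keeping the chain short, so a gain relative to compound 2 is expected, though whether it reaches the level of compound 1 cannot be read from one step.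

The expected outcome for compound 4 is a number 16.9 percentage points higher from compound 2 to compound 4 (beyond the scatter), an estimate of 44% with a range from 28% to 60%.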

Compound 4, largest response reached (reported as percent of maximum), in percent of the reference or control that the assay uses: 16.3%
Compound 4: the middle estimate sits 27.7 percentage points above what was measured; the whole stated range lies above it.
By their numbers in this assay, from the lowest: compounds 4, 3 and 2 (each within the scatter of the next, the first and the last beyond it); then compound 1.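

Removing the branching methyl does not restore the response: there is a number 10.8 percentage points lower from compound 2 to compound 4 (beyond the scatter) and not a gain, so the ethyl ketone falls further from the propyl ketone than the isopropyl ketone does, and the earlier loss cannot be read as a cost of branching alone. The methyl on a saturated chain carbon, two bonds along the chain from a carbonyl carbon, carries the largest of the three ketone steps, since hydrogen in its place gives a number 36.7 percentage points lower from compound 1 to compound 4 (beyond the scatter) and leaves propyl above both isopropyl and ethyl, with neither of these two compounds going against that order. Nothing shown gives a reason for either step.

Going by these compounds, what remains open is whether the response keeps rising with a longer chain on the carbonyl carbon, such as butyl or pentyl, or whether propyl is already the best of that line. Also open, on these data alone, is whether a cyclopropyl group on the same carbonyl carbon, which would keep the chain compact in a ring, behaves like the propyl ketone or like the isopropyl ketone.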